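Selenium to sulfur on the core of compound 1

A few compounds are considered here, and "the series" means these few. Any claim that something is new, unique, unknown or untested is made for them only; others in the source may bear on it.

Compound 1 `COc1ccc(CNc2nc([SeH])nc3ccccc23)cc1` gives the lowest of the two numbers in hand. In a functional assay on HTB-54 cells (Homo sapiens) for cytotoxicity, read by MTT assay, with a stated time of 72 h (on this read-out higher numbers stand for weaker inhibition of growth and lower numbers for stronger inhibition of growth), compound 1 gives 7110 nM. For the measured compounds named here, its only measured neighbour, compound 2 `CSc1ccc(CNc2nc([SeH])nc3ccccc23)cc1`, gives 45500 nM in this assay, and the step of a 6.4-fold higher number from compound 1 to compound 2 (0.81 log units; beyond the scatter) replaces methylsulfanyl with methoxy on an aromatic carbon of the outer ring.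

Compound 3 `COc1ccc(CNc2nc(S)nc3ccccc23)cc1` has not been measured. The change from compound 1 to compound 3 is one sulfur atom in place of one selenium atom, on an aromatic carbon between two ring nitrogen atoms of the shared core. Going by the values given here, no measured step touches this position or this kind of exchange; the step from compound 1 to compound 2 concerns a different ring and a different group, so it gives no direct guide. With nothing to anchor a direction, the expected step of a 1.7-fold higher number from compound 1 to compound 3 (0.23 log units; within the scatter) is small and its range wide. On this basis compound 3 is estimated at 12000 nM in this assay, with a range from 4000 nM to 50000 nM.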

Compound 3, concentration for 50% growth inhibition: 13500 nM
The estimate for compound 3 lay 1.1-fold (0.05 log units) below the measured number; the measured number falls inside the stated range.
By their numbers in this assay, from the lowest: compounds 1 and 3 (each within the scatter of the next); then compound 2.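

In this assay, for the compounds shown here, the exchange of selenium for sulfur gives a 1.9-fold higher number from compound 1 to compound 3 (0.28 log units; within the scatter), the first measured reading of any change at this carbon of the shared core, and by that reading compound 1 and compound 3 cannot be told apart. Selenium is therefore not required at this position for the growth inhibition seen with compound 1, at least with methoxy on the outer ring, whereas the earlier change on that outer ring gave a 6.4-fold higher number from compound 1 to compound 2 (0.81 log units; beyond the scatter) and stood beyond the scatter. No measurement shown here accounts for how closely compound 1 and compound 3 agree, and the sulfanyl and selenium forms can only be compared by their numbers in this one assay.

Going by these compounds, it remains open whether an amine, a hydroxyl or a methylsulfanyl group on the same carbon would also stay within the scatter of compound 1, or whether only sulfanyl does so. On these data alone, it is also open whether the same exchange would read alike on compound 2, which carries methylsulfanyl on the outer ring, and whether the match between compound 1 and compound 3 holds in other cells.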